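This account rests on a few compounds, and the source may have more. Where it says the series, first, only, none or still open, it means among the compounds named here.

Three compounds share one core and differ only in the group attached to one aromatic carbon. Compound 1 `C/C(=N\Nc1nc(-c2ccc(Br)cc2)cs1)c1cc2ccccc2o1` gives 32700 nM in a functional assay on HeLa cells (Homo sapiens) for antiproliferative activity; on this read-out higher numbers stand for weaker inhibition and lower numbers for stronger inhibition. Compound 2 `C/C(=N\Nc1nc(-c2ccc(Cl)cc2)cs1)c1cc2ccccc2o1` gives 26600 nM in this assay, and compound 3 `C/C(=N\Nc1nc(-c2ccccc2)cs1)c1cc2ccccc2o1` gives 11700 nM in this assay. Compound 2 therefore stands second highest of the three numbers: it sits within the scatter of compound 1 and is separated only from compound 3. The two steps that touch compound 2 are a 1.2-fold lower number from compound 1 to compound 2 (0.09 log units; within the scatter) and a 2.3-fold lower number from compound 2 to compound 3 (0.36 log units; beyond the scatter), the second being modest. Compound 4 `C/C(=N\Nc1nc(-c2cc3ccccc3o2)cs1)c1cc2ccccc2o1` carries 1-benzofuran-2-yl in place of 4-chlorophenyl on an aromatic carbon. For the measured compounds named here, no measured step replaces the whole phenyl ring by a two-ring group, so the change is only loosely covered; the nearest guide is the modest gain seen on removing the halogen, a 2.3-fold lower number from compound 2 to compound 3 (0.36 log units; beyond the scatter). For compound 4 the expected step in this assay is a 1.8-fold lower number from compound 2 to compound 4 (0.25 log units; within the scatter), with wide uncertainty in both directions. Compound 4 is estimated at 15000 nM, with a range from 4000 nM to 50000 nM.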

Compound 4, half-maximal inhibitory concentration: 24100 nM
Compound 4: the middle estimate sits 1.6-fold (0.21 log units) below what was measured; low and high end bracket the measured number.
By their numbers in this assay, from the lowest: compound 3; then compounds 4, 2 and 1 (each within the scatter of the next).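

In this assay, replacing the whole 4-chlorophenyl with the two-ring 1-benzofuran-2-yl leaves the number within the scatter (a 1.1-fold lower number from compound 2 to compound 4 (0.04 log units; within the scatter)), and the same holds when compound 4 is set against the 4-bromophenyl compound (a 1.4-fold lower number from compound 1 to compound 4 (0.13 log units; within the scatter)). This position on the shared core therefore accepts a much bigger change than a swap of halogen without a clear shift, yet the plain phenyl of compound 3 still stands apart, with a modest step beyond the scatter (a 2.1-fold higher number from compound 3 to compound 4 (0.31 log units; beyond the scatter)). No measurement shown here explains these differences.

For the compounds shown here, all the groups at this position so far are aromatic rings, so it remains open how an amine, a morpholine ring or a short alkyl chain would compare. A pyridine ring in place of the phenyl is equally untested among the compounds shown.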